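Sulfone Aryl Exchange and Expected Liver Clearance

The source may hold more compounds than are shown below. What is called first, only, known or untested is meant among the compounds shown, and "the series" means these compounds.

Measured compounds:
compound 1 `COc1ccc(-c2c(S(=O)(=O)c3cccc(C#N)c3)cnc3cc(F)ccc23)cc1`, 0.92 mL/min
compound 2 `N#Cc1cccc(S(=O)(=O)c2cnc3cc(F)ccc3c2-c2cccc(Cl)c2)c1`, 0.99 mL/min
compound 3 `COc1cccc(-c2c(S(=O)(=O)c3cc(F)cc(F)c3)cnc3c(F)cccc23)c1`, 2.76 mL/min

In an ADME assay on microsomes from liver (Homo sapiens) for metabolic stability, tested at 2.5 uM (a higher number here means faster removal of the compound, a lower number slower removal), compound 1 gives the lowest of the three numbers. Compound 2 sits nearest, and a 1.1-fold higher number from compound 1 to compound 2 (0.03 log units; within the scatter); compound 3 stands furthest, beyond the scatter. Compound 4 `COc1ccc(-c2c(S(=O)(=O)c3cc(F)cc(F)c3)cnc3cc(F)ccc23)cc1` is not yet measured; it differs from compound 1 by 3,5-difluorophenyl in place of 3-cyanophenyl on a sulfonyl sulfur. Among the compounds with values here, no measured step covers this exchange on the sulfonyl sulfur: the only step on record changes the aryl group on an aromatic carbon and stays within the scatter. Compound 3, which also carries a 3,5-difluorophenyl on the sulfonyl sulfur, differs from compound 4 in more than one place, so its higher number is only a loose hint. Compound 4 is therefore expected to move upward modestly, a 1.7-fold higher number from compound 1 to compound 4 (0.24 log units; within the scatter), with an estimate of 1.6 mL/min, between 0.8 mL/min and 3.2 mL/min.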

Compound 4, intrinsic clearance in a liver preparation (reported as CLH), per the amount of preparation that the assay uses: 1.51 mL/min
Beside the measured number, compound 4's estimate is 1.1-fold (0.03 log units) above it; the range from low to high includes it.
By their numbers in this assay, from the lowest: compounds 1, 2, 4 and 3 (each within the scatter of the next, the first and the last beyond it).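

In this assay, 3,5-difluorophenyl in place of 3-cyanophenyl on a sulfonyl sulfur gives a 1.6-fold higher number from compound 1 to compound 4 (0.22 log units; within the scatter). Within the data shown here, this is the first reading of an exchange at this position, and with the rest of compound 1 held constant, it shows that this pair of aryl groups cannot be told apart here. Nothing at hand explains this reading.

As far as these compounds go, it remains open whether the same exchange would read alike with 3-chlorophenyl on the aromatic carbon. Also open, from the compounds shown here alone, is how a sulfonyl aryl group bearing an amine or a carboxylic acid would read.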